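Removing the Methoxy Group from a Pyridyl Ether

The compounds below may be only part of what the source reports. "The series", "measured", "known", "first", "only" and "open" are said of these compounds alone.

Three measured compounds share one core and differ only in the aromatic group attached through an oxygen on a saturated carbon. In an ADME assay on PBMC cells (Homo sapiens) for cytotoxicity (on this read-out lower numbers stand for higher toxicity in this test and higher numbers for lower toxicity in this test), compound 1 `Cc1ccnc(OC(c2ccc(C(F)(F)F)cc2)C2CCN(C(C)CCNC(=O)c3c(Cl)cncc3Cl)CC2)c1` gives 33600 nM. Compound 2 `CC(CCNC(=O)c1c(Cl)cncc1Cl)N1CCC(C(Oc2cccc(C(F)(F)F)c2)c2ccc(C(F)(F)F)cc2)CC1` gives 7000 nM in this assay. Compound 3 `COc1cccc(OC(c2ccc(C(F)(F)F)cc2)C2CCN(C(C)CCNC(=O)c3c(Cl)cncc3Cl)CC2)n1` gives 32700 nM in this assay. The step of a 1.0-fold lower number from compound 1 to compound 3 (0.01 log units; within the scatter) leaves compound 3 and compound 1 within the scatter of each other, whereas a 4.7-fold higher number from compound 2 to compound 3 (0.67 log units; beyond the scatter) sets compound 3 apart from compound 2 beyond the scatter, and a 4.8-fold lower number from compound 1 to compound 2 (0.68 log units; beyond the scatter) shows the same gap from the other side.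

Compound 4 `CC(CCNC(=O)c1c(Cl)cncc1Cl)N1CCC(C(Oc2ccccn2)c2ccc(C(F)(F)F)cc2)CC1` has not yet been measured. It differs from compound 3 by hydrogen in place of methoxy on an aromatic carbon. Among the measured compounds shown here, no measured step removes exactly this group, so the nearest guide is the comparison of compound 1 with compound 3, where exchanging one small substituent on the pyridine for another gave a 1.0-fold lower number from compound 1 to compound 3 (0.01 log units; within the scatter). A similarly small effect is therefore expected here, meaning an estimated 1.2-fold lower number from compound 3 to compound 4 (0.07 log units; within the scatter) with no shift beyond the scatter. Compound 4 is expected to give about 28000 nM in this assay, within a range from 12000 nM to 60000 nM.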

Compound 4, half-maximal cytotoxic concentration: 34100 nM
Estimate against measurement, compound 4: 1.2-fold (0.09 log units) below; the measured number falls inside the stated range.
By their numbers in this assay, from the lowest: compound 2; then compounds 3, 1 and 4 (each within the scatter of the next).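

The pyridine ring with no substituent can't be told apart from either substituted pyridine: in this assay hydrogen in place of methoxy gives a 1.0-fold higher number from compound 3 to compound 4 (0.02 log units; within the scatter) and hydrogen in place of methyl gives a 1.0-fold higher number from compound 1 to compound 4 (0.01 log units; within the scatter) on the same ring. Among these compounds, the gap to the 3-(trifluoromethyl)phenyl ether therefore does not rest on a pyridine substituent, as pyridin-2-yl in place of that group still gives a 4.9-fold higher number from compound 2 to compound 4 (0.69 log units; beyond the scatter) and this step lies beyond the scatter. Nothing available here explains either the gap or the absence of an effect at this position.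

The compounds shown leave open whether a larger or charged substituent on the pyridine, such as an amine or a carboxylic acid, would also stay within the scatter. They also leave open whether a plain phenyl ring, without trifluoromethyl, would sit with compound 2 or with the pyridines.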